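The compounds below may be only part of what the source reports. "The series", "measured", "known", "first", "only" and "open" are said of these compounds alone.

Compound 1 `O=C(CN(c1ncnc2c1ncn2C1CCCCO1)C1CC1)N[C@@H](CCC(=O)OCc1ccccc1)C(=O)OCc1ccccc1` was tested in a functional assay on the whole organism (Tail, strain ICR) with Mus musculus as the target, in the tail flick test, with a stated time of 90 min, at a dose of 25 umol/kg by the oral route (a higher number here means a stronger effect of the compound at the dose given, a lower number a weaker effect), where compound 1 gives 25.2%. Two other compounds were run in the same test: compound 2 `NC(=O)C[C@H](NC(=O)CN(c1nc(Cl)nc2[nH]cnc12)C1CC1)C(=O)O` gives 20.1% in this assay, and compound 3 `CC(C)C[C@H](NC(=O)CN(c1nc(Cl)nc2[nH]cnc12)C1CC1)C(=O)OCc1ccccc1` gives 15.2%. Compound 1 sits at the upper end of these three numbers, but the gaps to compound 2 and to compound 3 both fall within the usual scatter of repeated measurements, so the three compounds are not separated by this assay.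

The step under consideration leads from compound 1 to compound 4 `CC(C)C[C@H](NC(=O)CN(c1ncnc2c1ncn2C1CCCCO1)C1CC1)C(=O)OCc1ccccc1`, which has not yet been measured in this assay. The change is as follows: isopropyl in place of (benzyloxycarbonyl)methyl on a saturated chain carbon, two bonds along the chain from an amide-type nitrogen and a carbonyl carbon. The rest of the molecule, including the shared core of compound 1, is kept.

Going by the values given here, no measured pair shows this change on its own, so its effect has to be estimated. Because compound 3 gives 15.2% in this assay, a small downward step or none beyond the scatter is expected, and the step from compound 1 to compound 4 is estimated as a number 5.2 percentage points lower from compound 1 to compound 4 (within the scatter). For compound 4 the expected value in this assay is 20%, with a range from 8% to 32%.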

Compound 4, a percentage reported as activity, at one dose (the size of the read-out at that dose, not a potency): 28.2%
For compound 4 the middle estimate is 8.2 percentage points below the measured one, and the stated range covers the measured number.
By their numbers in this assay, from the lowest: compounds 3, 2, 1 and 4 (each within the scatter of the next, the first and the last beyond it).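

In this assay, going by these compounds alone, the exchange reads as a number 3 percentage points higher from compound 1 to compound 4 (within the scatter) and so does not separate the two compounds, which is the first direct reading at this position, on a saturated chain carbon, two bonds along the chain from an amide-type nitrogen and a carbonyl carbon. The read-out stays within the scatter with isopropyl in place of (benzyloxycarbonyl)methyl, although the group that leaves carries a six-membered aromatic ring of carbon only and hydrogen-bond acceptors, and the group that enters carries neither. Nothing available explains this outcome.

As far as these compounds go, whether a carboxylic acid, an amine or a longer alkyl chain at this position would give a step beyond the scatter remains open. From the compounds shown here alone, with a single step read at one dose and one time point, it is also open whether compound 1 and compound 4 would remain inseparable under other conditions of the test.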